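The compounds below may be only part of what the source reports. "The series", "measured", "known", "first", "only" and "open" are said of these compounds alone.

Measured compounds:
compound 1, `CC(C)c1ccc(-c2nc(CN3CCCC3)nn2C)cc1`, 96 nM in an assay on membranes from Jurkat cells for displacement of a labelled ligand from Sigma non-opioid intracellular receptor 1 (Homo sapiens), read by scintillation counting, with a stated time of 2 h; on this read-out lower numbers stand for stronger inhibition and higher numbers for weaker inhibition
compound 2, `Cn1nc(CN2CCCC2)nc1-c1cccc(C(C)(C)C)c1`, 29 nM in this assay

Of these two numbers, compound 1 has the higher one, so it is the weaker binder; the gap between compound 1 and compound 2 is beyond the usual scatter, with compound 2 the stronger of the two. For the measured compounds named here, the next compound keeps the core of compound 1 and changes only one group. Compound 3, `Cn1nc(CN2CCCC2)nc1-c1ccc(C(F)(F)F)cc1`, carries trifluoromethyl in place of isopropyl on an aromatic carbon. Going by the values given here, no measured pair shows this particular change, so the size of the step has to be guessed from the two values alone: the change keeps a group of roughly similar bulk on the same aromatic carbon, and the expected step is small, in either direction, and quite possibly within the scatter. The estimate for a 1.0-fold higher number from compound 1 to compound 3 (0.02 log units; within the scatter) is therefore close to no change. For compound 3 in this assay the expected value is 100 nM, with a likely range from 35 nM to 300 nM.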

Compound 3, inhibition constant: 82 nM
The estimate for compound 3 lay 1.2-fold (0.09 log units) above the measured number; the range from low to high includes it.
By their numbers in this assay, from the lowest: compound 2; then compounds 3 and 1 (each within the scatter of the next).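

In this assay, putting trifluoromethyl in place of isopropyl on this aromatic carbon gives a 1.2-fold lower number from compound 1 to compound 3 (0.07 log units; within the scatter) and so leaves the reading within the scatter. This is the first pair shown that differs in one place only, and it shows that at this position a group of carbon alone can give way to one carrying fluorine without a change that can be told from the scatter. Nothing measured here explains why the two groups read alike.

Still open, as far as these compounds go, is how a hydrogen, a methoxy group, a nitrile or an amine on this carbon would compare with compound 1 and compound 3. Also open, from the compounds shown here alone, is whether the same swap would read alike on another carbon of this aromatic ring.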